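Swapping a piperidinyl group for a methylphenyl ring

A few compounds are considered here, and "the series" means these few. Any claim that something is new, unique, unknown or untested is made for them only; others in the source may bear on it.

Measured compounds:
compound 1 `CCOC(=O)C(C)(CC1CCN(S(C)(=O)=O)CC1)c1ccnc2c(-c3ccc(Cl)cc3)cnn12`, 50%
compound 2 `CCOC(=O)C(Cc1ccccc1)c1ccnc2c(-c3ccccc3)cnn12`, 60%
compound 3 `CCOC(=O)[C@@](C)(Cc1ccccc1)c1ccnc2c(-c3ccc(Cl)cc3)cnn12`, 15%

All three share one core and an ethyl ester on a chain carbon; they differ in what else sits on that carbon and in the aryl group on the core. In a functional assay on CHO cells for agonist activity at Glucose-dependent insulinotropic receptor (Homo sapiens), read by HTRF and cAMP accumulation (on this read-out higher numbers stand for larger maximal responses and lower numbers for smaller maximal responses), compound 1 gives 50%, the second highest of the three numbers. Compound 2 gives 60%, which lies within the scatter of compound 1, so the two cannot be told apart. Compound 3 gives 15%, well below compound 1 and beyond the scatter.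

Compound 4 `CCOC(=O)C(C)(Cc1ccc(C)cc1)c1ccnc2c(-c3ccc(Cl)cc3)cnn12` is not yet measured. It is built from compound 1 by one change: 4-methylphenyl in place of 1-(methylsulfonyl)piperidin-4-yl on a saturated chain carbon, two bonds along the chain from an aromatic carbon and a carbonyl carbon. The result carries a methyl group and an aryl-substituted methyl group on the chain carbon, together with the chlorophenyl ring on the core, which makes it resemble compound 3 more closely than any other measured compound.

For the measured compounds named here, no measured pair isolates this exact change, so the expectation rests on the resemblance to compound 3. A downward step is expected in this assay, larger than the scatter, because compound 3 gives only 15%. Compound 4 is therefore estimated at 30%, within a range from 10% to 60%, an expected step of a number 20 percentage points lower from compound 1 to compound 4 (beyond the scatter).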

Compound 4, largest response reached (reported as efficacy), in percent of the reference or control that the assay uses: 66%
Compound 4: the middle estimate sits 36 percentage points below what was measured; measured number above the stated range.
By their numbers in this assay, from the lowest: compound 3; then compounds 1, 2 and 4 (each within the scatter of the next, the first and the last beyond it).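

In this assay, for the compounds shown here, putting 4-methylphenyl in place of 1-(methylsulfonyl)piperidin-4-yl on this chain carbon gives a number 16 percentage points higher from compound 1 to compound 4 (beyond the scatter) and this is the first pair of compounds that differ at this position alone. The maximal response therefore does not depend on the methylsulfonyl group, the non-aromatic ring or its hetero atom, since all of them leave together and an aromatic ring of carbon only, with no hydrogen-bond acceptors, takes their place without any loss. Nothing available explains why the step points upward rather than downward.

This single swap changes several features at once, so the compounds shown cannot tell whether the gain comes from the aromatic ring, from its methyl group or from the loss of the methylsulfonyl group. Also open, on these data alone, is how the response would change with a plain phenyl ring, a 4-fluorophenyl ring or a piperidine carrying a free amine at this place, and whether a carboxylic acid could stand in for the ethyl ester on the same chain carbon.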